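Swapping the aryl on the ring nitrogen of compound 3

The source may report more compounds than this note shows. Statements on the series, on what has been measured and on what is new or still open speak of the compounds shown alone.

Measured so far:
compound 1, `O=C1COc2ccc(-c3[nH]c(-c4ccc(C(F)(F)F)cc4)nc3-c3ccccc3)cc2N1`, 95%
compound 2, `O=C1COc2ccc(-c3[nH]c(-c4ccc(F)cc4)nc3-c3ccccc3)cc2N1`, 94.8%
compound 3, `O=C1COc2ccc(-c3nn(-c4ccc(F)cc4)cc3-c3ccccc3)cc2N1`, 64.4%

Among the measured compounds shown here, in a functional assay on DLD-1 cells (Homo sapiens) for cytotoxicity, read by colorimetric assay and MTT assay, with a stated time of 3 days, tested at 1 uM (a higher number here means a weaker effect of the compound at the concentration tested, a lower number a stronger effect), compound 1 gives 95% and compound 2 gives 94.8%; the one measured step between them, a number 0.2 percentage points lower from compound 1 to compound 2 (within the scatter), is within the scatter. Compound 3 stands lowest of the three in this assay with 64.4%, and its gap to each of compound 1 and compound 2 lies beyond the scatter, so compound 3 is the strongest of the three.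

Compound 4, `Cc1ccccc1-n1cc(-c2ccccc2)c(-c2ccc3c(c2)NC(=O)CO3)n1`, has not yet been measured. It differs from compound 3 by 2-methylphenyl in place of 4-fluorophenyl on an aromatic nitrogen. For the measured compounds named here, no measured step touches this kind of change: the only step on record, a number 0.2 percentage points lower from compound 1 to compound 2 (within the scatter), concerns a substituent on an aromatic carbon, not a group on the ring nitrogen, and it was within the scatter. There is therefore no basis for expecting a step beyond the scatter in this assay from compound 3 to compound 4, in either direction. Compound 4 is expected to show a number 1.6 percentage points higher from compound 3 to compound 4 (within the scatter), and its value in this assay is estimated at 66%, within a range from 45% to 88%.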

Compound 4, a percentage reported as activity, at one concentration (the size of the read-out at that concentration, not a potency): 92.2%
The estimate for compound 4 lay 26.2 percentage points below the measured number; the measured number lies above the stated range.
By their numbers in this assay, from the lowest: compound 3; then compounds 4, 2 and 1 (each within the scatter of the next).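

In this assay, 2-methylphenyl in place of 4-fluorophenyl on the aromatic nitrogen gives a number 27.8 percentage points higher from compound 3 to compound 4 (beyond the scatter), so the effect at the concentration tested is weaker in compound 4. Among the compounds shown here, this is the first step on record beyond the scatter, and it shows that this ring nitrogen is sensitive to the aryl it carries, even though neither group has a hydrogen-bond donor or acceptor. Nothing measured here bears on what lies behind this step.

The change alters both the substituent and its place on the phenyl ring, so these two compounds cannot show which of the two matters. From the compounds shown here alone, it also remains open how a plain phenyl on this nitrogen, or a phenyl bearing an amine or a carboxylic acid, would behave.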